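The source may hold more compounds than are shown below. What is called first, only, known or untested is meant among the compounds shown, and "the series" means these compounds.

Compound 1 `Cc1ccc(OCC(=O)N(Cc2cccs2)c2ccnn2C)cc1`: 422 nM
Compound 2 `Cc1ccc(OCC(=O)N(CCCO)Cc2cccs2)cc1`: 3000 nM
Compound 3 `CCN(Cc1ccccc1)C(=O)COc1ccc(C)cc1`: 1880 nM

All three were tested in an assay on HEK293 cells for agonist activity at transient receptor potential cation channel subfamily M member 8 (Homo sapiens), read by fluorescence and calcium flux, with a stated time of 15 min; a higher number here means that more compound is needed for the effect, a lower number that less compound is needed. Among them compound 2 carries the highest of the three numbers, although compound 3 sits within the scatter of it, so the two cannot be separated; compound 1 lies furthest from compound 2, beyond the scatter.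

The next compound is compound 4 `Cc1ccc(OCC(=O)N(Cc2cccs2)c2c(C)n[nH]c2C)cc1`. It is derived from compound 2 by this change: 3,5-dimethyl-1H-pyrazol-4-yl in place of 3-hydroxypropyl on an amide-type nitrogen

Going by the values given here, only one measured step bears on this. The step of a 7.1-fold higher number from compound 1 to compound 2 (0.85 log units; beyond the scatter) shows that exchanging an aromatic pyrazolyl on the amide-type nitrogen for the 3-hydroxypropyl chain made the number rise. Compound 4 goes the opposite way, putting a pyrazolyl back in place of that chain, though the ring now is 3,5-dimethyl-1H-pyrazol-4-yl rather than 1-methyl-1H-pyrazol-5-yl, so the return need not be complete. On this basis the number in this assay is expected to fall from compound 2 to compound 4 by roughly the size seen before, a 4.6-fold lower number from compound 2 to compound 4 (0.66 log units; beyond the scatter). For compound 4 the estimated value is 650 nM, with a range from 200 nM to 2000 nM.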

Compound 4, half-maximal effective concentration: 0.3 nM
Compound 4: middle estimate off by 2200-fold (3.34 log units), on the high side; the whole stated range lies above it.
By their numbers in this assay, from the lowest: compound 4; then compound 1; then compounds 3 and 2 (each within the scatter of the next).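

In this assay, going by these compounds alone, the group on the amide-type nitrogen proves far more decisive than the one earlier step, a 7.1-fold higher number from compound 1 to compound 2 (0.85 log units; beyond the scatter), could suggest: putting 3,5-dimethyl-1H-pyrazol-4-yl in place of the 3-hydroxypropyl chain gives a 10000-fold lower number from compound 2 to compound 4 (4.00 log units; beyond the scatter). Within the data shown here, the comparison of the two rings adds what the earlier compounds could not show: the presence of a pyrazolyl ring at this place does not by itself set the number, since 3,5-dimethyl-1H-pyrazol-4-yl in place of 1-methyl-1H-pyrazol-5-yl gives a 1400-fold lower number from compound 1 to compound 4 (3.15 log units; beyond the scatter), so the identity of the ring and its substituents matters greatly. Nothing available here accounts for so wide a gap between the two rings.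

The compounds shown leave open which feature of the 3,5-dimethyl-1H-pyrazol-4-yl group carries the gain, for instance whether a plain 1H-pyrazol-4-yl without the two methyl groups, or a 3,5-dimethylisoxazol-4-yl, would keep a number near that of compound 4. They also leave open how a simple phenyl or a 3-aminopropyl chain on this nitrogen would compare.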